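A few compounds are considered here, and "the series" means these few. Any claim that something is new, unique, unknown or untested is made for them only; others in the source may bear on it.

Among the compounds with values here, in a functional assay on DU-145 cells (Homo sapiens) for cytotoxicity, read by MTT assay (a higher number here means a weaker inhibitor, a lower number a stronger inhibitor), three compounds with a shared core have numbers so far: compound 1 `COc1ccc(CSc2nnc([C@@H](C)c3ccc4cc(OC)ccc4c3)n2-c2ccc(Cl)cc2)cc1` gives 72600 nM, compound 2 `COc1ccc2cc([C@H](C)c3nnc(SCc4ccc(Cl)cc4)n3-c3ccc(Cl)cc3)ccc2c1` gives 109000 nM, and compound 3 `COc1ccc2cc([C@H](C)c3nnc(SCc4ccc(C)cc4)n3-c3ccc(Cl)cc3)ccc2c1` gives 18800 nM. Compound 3 therefore stands lowest of the three, and its steps to both others lie beyond the scatter. Compound 4 `COc1ccc2cc([C@H](C)c3nnc(SCc4c(Cl)cccc4Cl)n3-c3ccc(Cl)cc3)ccc2c1` differs from compound 3 on a saturated chain carbon bound to a sulfur, where 4-methylbenzyl gives way to 2,6-dichlorobenzyl: 2,6-dichlorophenyl in place of 4-methylphenyl on a saturated chain carbon bound to a sulfur.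

Within the data shown here, no measured step makes this exact change. The nearest evidence is a modest 5.8-fold lower number from compound 2 to compound 3 (0.76 log units; beyond the scatter) for methyl in place of chloro on an aromatic carbon, and a modest 3.9-fold lower number from compound 1 to compound 3 (0.59 log units; beyond the scatter) for methyl in place of methoxy. By contrast, a 1.5-fold higher number from compound 1 to compound 2 (0.18 log units; within the scatter) stays within the scatter. Among these three compounds, the methyl compound has the lowest number, and none goes against that. Compound 4 has no methyl group and carries chlorine instead, so a modest rise in this assay is expected. Among the measured compounds shown here, no measured compound carries the 2,6-dichlorophenyl group, however, so the size remains uncertain. The estimated change is a 2.9-fold higher number from compound 3 to compound 4 (0.47 log units; beyond the scatter). For compound 4 the expected value is 55000 nM, with an estimated range of 15000 nM to 150000 nM.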

Compound 4, half-maximal inhibitory concentration: 36100 nM
Compound 4: the middle estimate sits 1.5-fold (0.18 log units) above what was measured; low and high end bracket the measured number.
By their numbers in this assay, from the lowest: compounds 3, 4, 1 and 2 (each within the scatter of the next, the first and the last beyond it).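

In this assay, within the data shown here, the earlier compounds showed only groups with one substituent on the ring at this saturated chain carbon bound to a sulfur, and compound 4 shows that the chlorine pattern on that ring matters: replacing 4-chlorophenyl with 2,6-dichlorophenyl gives a 3.0-fold lower number from compound 2 to compound 4 (0.48 log units; beyond the scatter), a modest step. Set against 4-methylphenyl, the same group gives a 1.9-fold higher number from compound 3 to compound 4 (0.28 log units; within the scatter), and against 4-methoxyphenyl it gives a 2.0-fold lower number from compound 1 to compound 4 (0.30 log units; within the scatter), so a chlorine-bearing ring need not lie beyond the scatter of the methyl compound: compound 2 does, while compound 4 does not. Nothing measured on these compounds accounts for the difference between the two chlorinated groups.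

The compounds shown leave open whether the step from compound 2 to compound 4 follows from the second chlorine or from where the chlorines stand, which a 2-chlorophenyl or a 3,5-dichlorophenyl group at this place could separate. Also open, on these data alone, is what a 2,6-dimethylphenyl group, an amine on the ring or a longer chain leading to the ring would give in this assay.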